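The source may hold more compounds than are shown below. What is called first, only, known or untested is meant among the compounds shown, and "the series" means these compounds.

Measured in a functional assay on NCI-H838 cells (Homo sapiens) for antiproliferative activity, read by MTT assay, with a stated time of 72 h (a lower number here means a stronger inhibitor, a higher number a weaker inhibitor), each value a limit of the assay:
- Compound 1 `C=CC(=O)Nc1cc2c(Nc3ccc(OCc4cccc(F)c4)c(Cl)c3)ncnc2cc1OCc1cn(CCCC(=O)NO)nn1`: > 50000 nM
- Compound 2 `C=CC(=O)Nc1cc2c(Nc3ccc(OCc4cccc(F)c4)c(Cl)c3)ncnc2cc1OCc1cn(CCCCC(=O)NO)nn1`: > 50000 nM
- Compound 3 `C=CC(=O)Nc1cc2c(Nc3ccc(F)c(Cl)c3)ncnc2cc1OCc1cn(CCC(=O)NO)nn1`: > 50000 nM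

Compound 3 gives only a limit, > 50000 nM, and so has no number. The record so far is the limit of > 50000 nM in this assay, at which 3 of the 3 values shown sit. Compound 4 `C=CC(=O)Nc1cc2c(Nc3ccc(OCc4cccc(F)c4)c(Cl)c3)ncnc2cc1OCc1cn(CCC(=O)NO)nn1` differs from compound 3 as follows: (3-fluorobenzyl)oxy in place of fluoro on an aromatic carbon. In words, this is (3-fluorobenzyl)oxy in place of fluoro on an aromatic carbon. Within the data shown here, the one measured step, a step that the two limits leave unreadable from compound 1 to compound 2, concerns the chain and not this change, so it gives no size to carry over. Compound 2, which carries (3-fluorobenzyl)oxy, also gives only a limit, > 50000 nM, so no step beyond the scatter is expected in this assay. The expected change is a number no higher from compound 3 to compound 4 (the limit leaves the size open). For compound 4 the estimated value is 50000 nM, with an expected range of 20000 nM to 100000 nM.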

Compound 4, half-maximal inhibitory concentration: > 50000 nM
Compound 4: no number, only a limit (the forecaster's own chance of this, stated with the estimate: 75%); the middle value sits exactly at the limit.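

In this assay compound 4 gives > 50000 nM as a limit of the assay, so its steps from compound 1, compound 2 and compound 3 cannot be read. The compounds shown leave open whether the chain or the (3-fluorobenzyl)oxy group changes the read-out at all: the limit of > 50000 nM in this assay, at which 4 of the 4 values shown sit.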